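Swapping 4-Methylphenyl for 3-Chlorophenyl on the Amine

A few compounds are considered here, and "the series" means these few. Any claim that something is new, unique, unknown or untested is made for them only; others in the source may bear on it.

Three measured compounds share one core and differ only in the aryl group attached to an amine nitrogen. Compound 1 `Cc1ccc(NC2=CC(=O)c3nc4n(c3C2=O)[C@H]2OC[C@@H](O)[C@H]2OC4)cc1` carries a 4-methylphenyl group there, and in a functional assay on ECa-109 cells for inhibition, with ECa-109 cell line (Homo sapiens) as the target, read by sulforhodamine B assay (a lower number here means a stronger inhibitor, a higher number a weaker inhibitor), compound 1 gives 3480 nM. Compound 2 `Cc1ccc(NC2=CC(=O)c3c(nc4n3[C@H]3OC[C@@H](O)[C@H]3OC4)C2=O)cc1C` carries a 3,4-dimethylphenyl group; in this assay compound 2 gives 4090 nM, which sits within the usual scatter of the number for compound 1, so neither can be called the stronger inhibitor. Compound 3 `COc1ccccc1NC1=CC(=O)c2c(nc3n2[C@H]2OC[C@@H](O)[C@H]2OC3)C1=O` carries a 2-methoxyphenyl group. For compound 3 the result in this assay is a limit of the assay rather than a number, > 4000 nM (the limit of > 4000 nM in this assay, at which 1 of the 3 values shown sits). Within the data shown here, the single step that can be drawn, a step that the limit leaves unreadable from compound 2 to compound 3, therefore has no readable size.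

Compound 4 `O=C1C=C(Nc2cccc(Cl)c2)C(=O)c2c1nc1n2[C@H]2OC[C@@H](O)[C@H]2OC1` differs from compound 1 by 3-chlorophenyl in place of 4-methylphenyl on an amine nitrogen. Among the measured compounds shown here, no measured step exchanges a methyl for a chlorine, and the one step that does change the aryl group is unreadable, so there is nothing here to point firmly in either direction. Compound 4 is therefore expected to land close to compound 1, with an estimate of 3500 nM and a range from 1200 nM to 10000 nM. The expected step of a 1.0-fold higher number from compound 1 to compound 4 (0.00 log units; within the scatter) lies within the scatter.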

Compound 4, half-maximal inhibitory concentration: 4690 nM
Estimate against measurement, compound 4: 1.3-fold (0.13 log units) below; the range from low to high includes it.
By their numbers in this assay, from the lowest: compounds 1, 2 and 4 (each within the scatter of the next).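

Among these compounds, this is the first readable step that changes the aryl group on this amine nitrogen: in this assay, putting 3-chlorophenyl in place of 4-methylphenyl gives a 1.3-fold higher number from compound 1 to compound 4 (0.13 log units; within the scatter). The two groups have the same count of heavy atoms, and a chlorine-bearing aryl group here gives a number that cannot be told apart from that of the methyl-bearing one, so this swap shows no measurable difference in this assay. Compound 3 cannot join this comparison, as its result is a limit of the assay and not a number: the limit of > 4000 nM in this assay, at which 1 of the 4 values shown sits.

The step from compound 1 to compound 4 changes both the atom on the phenyl ring and its place in the group's name, so 4-chlorophenyl or 3-methylphenyl would be needed to tell those two changes apart. The compounds shown also leave open whether this nitrogen keeps the same number with something quite different on it, such as a phenyl ring bearing a carboxylic acid, or a plain alkyl chain instead of an aryl group.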